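A few compounds are considered here, and "the series" means these few. Any claim that something is new, unique, unknown or untested is made for them only; others in the source may bear on it.

In a functional assay on Huh-7 cells (Homo sapiens) for antiproliferative activity, with a stated time of 48 h (on this read-out higher numbers stand for weaker inhibition and lower numbers for stronger inhibition), two compounds sharing one core have been measured. Compound 1 `CCN(CC)c1ccc(-c2ccc(C#N)cc2)nn1` reads > 25000 nM, which is a limit of the assay and not a number. Among the measured compounds shown here, compound 2 `CCN(CC)c1ccc(-c2ccc(C(=O)OC)cc2)nn1` gives 90 nM, so it holds the only actual number so far. Compound 3 `CCN(CC)c1ccc(-c2ccc(C(=O)O)cc2)nn1` differs from compound 2 by hydrogen in place of methyl on an oxygen next to a carbonyl group, which turns methoxycarbonyl to carboxy. For the measured compounds named here, only one measured step bears on this, an at least 270-fold lower number from compound 1 to compound 2 (2.44 log units; beyond the scatter), a large step that brought in the methoxycarbonyl group now being altered. It does not cover this exact change, but given the size of an at least 270-fold lower number from compound 1 to compound 2 (2.44 log units; beyond the scatter), a large move toward weaker inhibition is expected in this assay. The expected step is a 33-fold higher number from compound 2 to compound 3 (1.52 log units; beyond the scatter). The estimate for compound 3 is 3000 nM, with an expected range of 200 nM to 25000 nM.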

Compound 3, half-maximal inhibitory concentration: > 25000 nM
Compound 3: no number, only a limit; the forecaster's own chance of this, stated with the estimate: 25%; middle value at least 8.3-fold (0.92 log units) from the limit.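

In this assay, the number reached with the methoxycarbonyl group depends on the methyl on its oxygen: hydrogen in its place gives an at least 270-fold higher number from compound 2 to compound 3 (2.44 log units; beyond the scatter), a large step. The carbonyl group alone, kept in compound 3, therefore does not hold the low number seen for compound 2. The value of compound 3 is a limit of the assay and not a number, and the step between compound 1 and compound 3 cannot be read, as both compounds stand at the same limit: the limit of > 25000 nM in this assay, at which 2 of the 3 values shown sit.

The compounds shown leave open whether a longer chain on this oxygen, such as the ethyl group of an ethoxycarbonyl, would keep the low number. They also leave open what a primary amide in place of the methoxycarbonyl group would give.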